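A few compounds are considered here, and "the series" means these few. Any claim that something is new, unique, unknown or untested is made for them only; others in the source may bear on it.

Measured in a functional assay on A549 cells (Homo sapiens) for cytotoxicity, read by sulforhodamine B assay, with a stated time of 48 h; on this read-out higher numbers stand for weaker inhibition of growth and lower numbers for stronger inhibition of growth:
Compound 1 `C=CC[C@@]12C[C@@H](C(=O)OC)N3[C@@H]1N(C(=N)[C@]3(Cc1ccccc1)N1CCCC1)c1ccc(Br)cc12` gives 12100 nM.
Compound 2 `COC(=O)[C@@H]1C[C@@]2(CC=C(C)C)c3ccccc3N3C(=N)C(C)(C)N1[C@H]32` gives 28300 nM.
Compound 3 `COC(=O)[C@@H]1C[C@@]2(CC=C(C)C)c3ccccc3N3C(=N)[C@H](Cc4ccccc4)N1[C@H]32` gives 24100 nM.

Compound 3 stands second highest of the three numbers; its nearest neighbour is compound 2 and its furthest is compound 1, and both gaps lie within the scatter, so the three do not separate on this read-out. Compound 4 `COC(=O)[C@@H]1C[C@@]2(CC=C(C)C)c3ccccc3N3C(=N)[C@H](C(C)(C)C)N1[C@H]32` has not yet been measured in this assay. It differs from compound 3 by tert-butyl in place of benzyl on a saturated ring carbon. For the measured compounds named here, no step between measured compounds bears on this change, and compound 2 and compound 3 lie within the scatter of each other. The step from compound 3 to compound 4 is expected to stay within the scatter, with no direction beyond it: a 1.0-fold lower number from compound 3 to compound 4 (0.00 log units; within the scatter). Compound 4 is estimated at 24000 nM, within 8000 nM to 70000 nM.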

Compound 4, concentration for total growth inhibition: > 100000 nM
Compound 4 gave a limit, no number; the forecaster's own chance of this, stated with the estimate: 10%; middle value at least 4.1-fold (0.61 log units) from the limit.
By their numbers in this assay, from the lowest: compounds 1, 3 and 2 (each within the scatter of the next, the first and the last beyond it). At a limit, above all of these: compound 4.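

In this assay compound 4 reads > 100000 nM, which is a limit and not a number: the limit of > 100000 nM in this assay, at which 1 of the 4 values shown sits. For the compounds shown here, until now no step bore on this saturated ring carbon; tert-butyl in place of benzyl gives an at least 4.1-fold higher number from compound 3 to compound 4 (0.61 log units; beyond the scatter), so the group here is not interchangeable. From the compounds shown here alone, the true size of the step stays unknown.

Whether the aromatic ring of benzyl or the entry of tert-butyl accounts for the step stays open. Going by these compounds, how cyclohexylmethyl or an aminobutyl chain would read at this carbon also stays open.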